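Chlorophenyl Position in a Cyclohexanone Series: Cytotoxicity Notes

The source may report more compounds than this note shows. Statements on the series, on what has been measured and on what is new or still open speak of the compounds shown alone.

Measured so far:
compound 1 `COc1cccc(/C=C2\CCC/C(=C\c3ccccc3Cl)C2=O)c1OC` — 44200 nM
compound 2 `COc1cccc(/C=C2\CCC/C(=C\c3cccc(Cl)c3)C2=O)c1OC` — 21400 nM
compound 3 `COc1ccc(/C=C2\CCC/C(=C\c3ccccc3Cl)C2=O)cc1OC` — 21600 nM

The three measured compounds and the unmeasured compound 4 `COc1ccc(/C=C2\CCC/C(=C\c3cccc(Cl)c3)C2=O)cc1OC` share a cyclohexanone core carrying two benzylidene arms; they differ in where the chlorine sits on one arm and in the arrangement of the two methoxy groups on the other. In an ADME assay on NHDF cells (Homo sapiens) for cytotoxicity, read by MTT assay, with a stated time of 72 h (a higher number here means a weaker inhibitor, a lower number a stronger inhibitor), compound 1 gives 44200 nM, compound 2 gives 21400 nM and compound 3 gives 21600 nM.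

One change recurs twice in the set: 3-chlorophenyl in place of 2-chlorophenyl on a double-bonded chain carbon bound to a double-bonded ring carbon. Made on the core of compound 1 it produced a 2.1-fold lower number from compound 1 to compound 2 (0.32 log units; beyond the scatter). The same change, (3-chlorophenyl in place of 2-chlorophenyl on a double-bonded chain carbon bound to a double-bonded ring carbon), leads from compound 3 to compound 4. The two cores on which it is made, that of compound 1 and that of compound 3, differ in more than one place, and the difference between them is not broken down here. Compound 3 and compound 2 give values within the scatter of each other, while compound 3 sits well apart from compound 1.

Going by the values given here, with only one prior instance to go on, the expectation for compound 4 rests on the step seen between compound 1 and compound 2 and on the value of compound 3. Among the compounds with values here, compound 4 is expected to show a 2.0-fold lower number from compound 3 to compound 4 (0.29 log units; within the scatter) in this assay, because a 2.1-fold lower number from compound 1 to compound 2 (0.32 log units; beyond the scatter) is the sole precedent for this change. The estimate for compound 4 in this assay is 11000 nM, expected to fall between 5000 nM and 25000 nM.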

Compound 4, half-maximal inhibitory concentration: 11900 nM
Compound 4: middle estimate off by 1.1-fold (0.03 log units), on the low side; the range from low to high includes it.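

In this assay the swap of 2-chlorophenyl for 3-chlorophenyl on a double-bonded chain carbon bound to a double-bonded ring carbon gives a 1.8-fold lower number from compound 3 to compound 4 (0.26 log units; within the scatter) and this step, taken alone, does not stand clear of the scatter. Set beside the earlier step on the core of compound 1, it shows no difference in size, so across these two cores the change carries over as far as the data can tell: the same change on two cores in this assay, a 2.1-fold lower number (0.32 log units; beyond the scatter) from compound 1 to compound 2 and a 1.8-fold lower number (0.26 log units; within the scatter) from compound 3 to compound 4, 1.1-fold (0.06 log units) apart, within the scatter of two such steps. This does not amount to a rule for the series: it rests on two cores that differ only in the arrangement of the two methoxy groups, one of the two steps lies within the scatter, and nothing here gives a reason for the agreement or says how the change would behave on a more distant core.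

Still open, going by these compounds, is whether the same step holds when the chlorine gives way to another group on that arm, such as a fluorine, a nitrile or an amine. Also open, on these data alone, is how a core carrying a carboxylic acid or a longer chain in place of the methoxy groups would respond to this change.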